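A tert-Butyl Group Added to a Breast-Cancer Cell Growth Inhibitor

A few compounds are considered here, and "the series" means these few. Any claim that something is new, unique, unknown or untested is made for them only; others in the source may bear on it.

Of the compounds shown here, three sharing a chlorinated pyrimidine-like core have been tested so far. Compound 1 `Cc1ccccc1Nc1nc(NC2CC2)ncc1Cl` carries a small cyclopropylamine; compound 2 `Cc1ccccc1Nc1nc(Nc2ccc(N3CCCCC3)cc2)ncc1Cl` and compound 3 `CN1CCN(c2ccc(Nc3ncc(Cl)c(Nc4ccccc4)n3)nc2)CC1` carry larger aryl amines. In a functional assay on MDA-MB-231 cells (Homo sapiens) for inhibition, read by CCK-8 assay, with a stated time of 48 h (a lower number here means a stronger inhibitor of growth, a higher number a weaker inhibitor of growth), compound 1 gives only a limit, > 100000 nM, namely (the limit of > 100000 nM in this assay, at which 1 of the 3 values shown sits). In this assay compound 2 gives 19900 nM. In this assay compound 3 gives 37400 nM, the higher of the two numbers, yet the gap to compound 2 is within the scatter of repeated measurements, so the two cannot be told apart.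

Compound 4 `CN1CCN(c2ccc(Nc3ncc(Cl)c(Nc4ccc(C(C)(C)C)cc4)n3)nc2)CC1` differs from compound 3 in one place: tert-butyl in place of hydrogen on an aromatic carbon. The tert-butyl group enters on an aromatic carbon of a six-membered aromatic ring of carbon only, para to a large group.

Among the measured compounds shown here, no measured pair shows such a change, so the expected step from compound 3 to compound 4 is small, a 1.5-fold lower number from compound 3 to compound 4 (0.17 log units; within the scatter), a change not beyond the scatter. For compound 4 the expected value in this assay is 25000 nM, with a range from 8000 nM to 80000 nM.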

Compound 4, concentration for 50% growth inhibition: 16200 nM
Estimate against measurement, compound 4: 1.5-fold (0.19 log units) above; measured number inside the range.
By their numbers in this assay, from the lowest: compounds 4, 2 and 3 (each within the scatter of the next, the first and the last beyond it). At a limit, above all of these: compound 1.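

In this assay, putting tert-butyl in place of hydrogen on this aromatic carbon gives a 2.3-fold lower number from compound 3 to compound 4 (0.36 log units; beyond the scatter) and so shows that growth inhibition is kept, and modestly improved, with this large group at this place. It is also the first change at a single place among the compounds shown, whereas the earlier compounds differ from one another in more than one place and could not show how this position responds on its own. Nothing measured here bears on why the number moves.

On these data alone, whether an ethyl chain, a methoxy group, an amine or a carboxylic acid at this same place would give a lower or a higher number remains open. As far as these compounds go, whether tert-butyl would have a similar effect on compound 2 also remains unknown.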